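Phenyl to tetrahydroisoquinoline at the chain end

The source may report more compounds than this note shows. Statements on the series, on what has been measured and on what is new or still open speak of the compounds shown alone.

Among the measured compounds shown here, in an assay on isolated protein for inhibition of Calpain-1 catalytic subunit (Homo sapiens) (on this read-out higher numbers stand for weaker inhibition and lower numbers for stronger inhibition), compound 2 `CCC(NC(=O)C(CC(C)C)NC(=O)OCc1ccccc1)C(=O)C(=O)NCCCc1ccccc1` gives 800 nM, the highest of the three numbers measured so far; compound 1 `CCC(NC(=O)C(CC(C)C)NC(=O)OCc1ccccc1)C(=O)C(=O)NCCCCCO` gives 500 nM and compound 3 `CCC(NC(=O)C(CC(C)C)NC(=O)OCc1ccccc1)C(=O)C(=O)NCc1nccc2ccccc12` gives 250 nM. Compound 4 `CCC(NC(=O)C(CC(C)C)NC(=O)OCc1ccccc1)C(=O)C(=O)NCCCN1CCc2ccccc2C1` differs from compound 2 by 1,2,3,4-tetrahydroisoquinolin-2-yl in place of phenyl on a saturated chain carbon, three bonds along the chain from an amide-type nitrogen. For the measured compounds named here, two measured steps bear on this. At the same place, a 1.6-fold higher number from compound 1 to compound 2 (0.20 log units; within the scatter). Going by the values given here, at the carbon bound to the amide-type nitrogen, a 3.2-fold lower number from compound 2 to compound 3 (0.51 log units; beyond the scatter), the only step beyond the scatter. Neither step argues for a higher number when a larger group carrying a nitrogen enters. Compound 4 is therefore expected to show a modest lowering, a 2.0-fold lower number from compound 2 to compound 4 (0.30 log units; within the scatter), which may still fall within the scatter. The estimate for compound 4 is 400 nM, with a range from 150 nM to 1000 nM.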

Compound 4, inhibition constant: 310 nM
Beside the measured number, compound 4's estimate is 1.3-fold (0.11 log units) above it, and the stated range covers the measured number.
By their numbers in this assay, from the lowest: compounds 3, 4, 1 and 2 (each within the scatter of the next, the first and the last beyond it).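

In this assay, among the compounds shown here, 1,2,3,4-tetrahydroisoquinolin-2-yl in place of phenyl gives a 2.6-fold lower number from compound 2 to compound 4 (0.41 log units; beyond the scatter), the first change on this saturated chain carbon, three bonds along the chain from an amide-type nitrogen, to go beyond the scatter. The other two steps, a 1.6-fold lower number from compound 1 to compound 4 (0.21 log units; within the scatter) and a 1.2-fold higher number from compound 3 to compound 4 (0.09 log units; within the scatter), stay within it, so compound 4 cannot be ordered against compound 1 or compound 3. Nothing at hand explains the step from compound 2. Whether the nitrogen or the added ring accounts for it stays open, as does the outcome with an open-chain amine such as diethylamino, or with a longer chain, at this place.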